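The source may report more compounds than this note shows. Statements on the series, on what has been measured and on what is new or still open speak of the compounds shown alone.

Compound 1 `COc1cccc(/C=C2\CCC/C(=C\c3ccc(Br)cc3)C2=O)c1OC` and compound 2 `COc1ccccc1/C=C1\CCC/C(=C\c2cccc(OC)c2OC)C1=O` share one core. Compound 3 `COc1ccc(/C=C2\CCC/C(=C\c3ccc(Br)cc3)C2=O)cc1OC` is built from the same atoms as compound 1 joined differently; the difference between the two cores is not broken down here. In a functional assay on MCF7 cells (Homo sapiens) for cytotoxicity, read by MTT assay, with a stated time of 72 h (a higher number here means a weaker inhibitor, a lower number a stronger inhibitor), compound 1 gives 13800 nM, compound 2 gives 12000 nM and compound 3 gives 6900 nM. All three values lie within the scatter of one another, so no order among them is claimed.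

One change recurs twice in the set: 2-methoxyphenyl in place of 4-bromophenyl on a double-bonded chain carbon bound to a double-bonded ring carbon. Measured on the core of compound 1, it gave a 1.2-fold lower number from compound 1 to compound 2 (0.06 log units; within the scatter). Compound 4 `COc1ccccc1/C=C1\CCC/C(=C\c2ccc(OC)c(OC)c2)C1=O` carries the same change on the core of compound 3, (2-methoxyphenyl in place of 4-bromophenyl on a double-bonded chain carbon bound to a double-bonded ring carbon), and has not yet been measured in this assay.

Because the step of a 1.2-fold lower number from compound 1 to compound 2 (0.06 log units; within the scatter) stayed within the scatter, the value of compound 4 is estimated at 6000 nM, with a range from 2500 nM to 14000 nM. The expected step of a 1.2-fold lower number from compound 3 to compound 4 (0.06 log units; within the scatter) would remain within the scatter as well. This rests on a single prior instance of the change, so the expectation is held loosely.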

Compound 4, half-maximal inhibitory concentration: 8000 nM
The estimate for compound 4 lay 1.3-fold (0.12 log units) below the measured number; low and high end bracket the measured number.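

In this assay, 2-methoxyphenyl in place of 4-bromophenyl on a double-bonded chain carbon bound to a double-bonded ring carbon gives a 1.2-fold higher number from compound 3 to compound 4 (0.06 log units; within the scatter), so on this second core too the change leaves the number within the scatter. Set side by side, the two instances of the change do not differ: the same change on two cores in this assay, a 1.2-fold lower number (0.06 log units; within the scatter) from compound 1 to compound 2 and a 1.2-fold higher number (0.06 log units; within the scatter) from compound 3 to compound 4, 1.3-fold (0.12 log units) apart, within the scatter of two such steps. Among the compounds shown here, for this series, that shows the change can be carried between the core of compound 1 and the core of compound 3 without a measurable shift, but with both steps this small it shows only that the two cores agree in the absence of a resolved effect, not that a real effect transfers, and it says nothing about any third core.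

The compounds shown leave open whether any replacement at this place moves the number beyond the scatter at all. A phenyl ring bearing an amine or a carboxylic acid would test this, as would a longer chain in place of the aromatic ring.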